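Urea in place of amide on the anilide carbonyl

The compounds below may be only part of what the source reports. "The series", "measured", "known", "first", "only" and "open" are said of these compounds alone.

Compound 1 `COc1cc(-c2nn(-c3cccc(NC(=O)c4cccc(C(F)(F)F)c4)c3)cc2-c2ccncc2)ccc1Cl`: in a functional assay on SF-268 cells (Homo sapiens) for inhibition, read by sulforhodamine B assay, with a stated time of 48 h (a higher number here means that more compound is tolerated, a lower number that less compound is tolerated), compound 1 gives > 50000 nM, a limit of the assay rather than a number.
Compound 2 `O=C(Nc1cccc(-n2cc(-c3ccncc3)c(-c3ccc(Cl)c(O)c3)n2)c1)Nc1ccc(Cl)c(C(F)(F)F)c1`: in this assay compound 2 gives > 32500 nM, likewise a limit of the assay.

Compound 1 therefore stands only at the limit of > 50000 nM in this assay, at which 1 of the 2 values shown sits. For the measured compounds named here, the one other value available is itself a limit, (the limit of > 32500 nM in this assay, at which 1 of the 2 values shown sits). Going by the values given here, with two limits and no numbers, no step between measured compounds can be stated, and no order between compound 1 and compound 2 can be claimed.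

Compound 3 `COc1cc(-c2nn(-c3cccc(NC(=O)Nc4ccc(Cl)c(Cl)c4)c3)cc2-c2ccncc2)ccc1Cl` is the untested member. Against compound 1 the difference is (3,4-dichlorophenyl)amino in place of 3-(trifluoromethyl)phenyl on a carbonyl carbon, on a carbonyl carbon whose other neighbour is an amide-type nitrogen; the amide of compound 1 thus becomes a urea in compound 3, while the rest of the shared core is kept. In this assay no step beyond the scatter is expected in either direction, and the most probable outcome is a further limit. Compound 3 is expected at 50000 nM, with a range from 20000 nM to 100000 nM. The expected step of a number no higher from compound 1 to compound 3 (the limit leaves the size open) is essentially none.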

Compound 3, concentration lethal to 50% of the cells: > 50000 nM
Compound 3 was reported as a limit (the forecaster's own chance of this, stated with the estimate: 80%); the middle value sits exactly at the limit.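

In this assay compound 3 gives > 50000 nM, a limit of the assay and not a number. For the compounds shown here, compound 1 also stands only at a limit, so no step between compound 1 and compound 3 can be read. Whether the urea of compound 3 and the amide of compound 1 differ at all in this assay remains open, as the compounds shown give only limits.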